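The source may report more compounds than this note shows. Statements on the series, on what has been measured and on what is new or still open speak of the compounds shown alone.

Three compounds on the shared core have numbers in an ADME assay for permeability, using PAMPA, at pH 7.4; a higher number here means that the compound crosses the layer faster, a lower number that the compound crosses the layer more slowly. Compound 1 `Cc1cc(NC(=O)Nc2ncccc2C)c2ccccc2n1` gives 369 10^-6 cm/s in this assay. Compound 3 `Cc1cc(NC(=O)Nc2cccnc2)c2ccccc2n1` gives 63 10^-6 cm/s in this assay. Compound 2 `Cc1cc(NC(=O)Nc2ccc(O)cc2)c2ccccc2n1` gives 3 10^-6 cm/s in this assay and stands lowest of the three: a 21-fold higher number from compound 2 to compound 3 (1.32 log units; beyond the scatter) and a 120-fold lower number from compound 1 to compound 2 (2.09 log units; beyond the scatter), both beyond the scatter. The third measured step is smaller, a 5.9-fold lower number from compound 1 to compound 3 (0.77 log units; beyond the scatter), modest next to those two.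

Compound 4 `Cc1cc(NC(=O)Nc2ccc(OC(F)(F)F)cc2)c2ccccc2n1` has not yet been measured in this assay. Against compound 2 the change is trifluoromethyl in place of hydrogen on an oxygen on an aromatic ring. Among the measured compounds shown here, no measured step swaps a hydrogen on that oxygen for a trifluoromethyl, so the nearest guides are the two steps that take the 4-hydroxyphenyl off the amide-type nitrogen, a 21-fold higher number from compound 2 to compound 3 (1.32 log units; beyond the scatter) and the reverse of a 120-fold lower number from compound 1 to compound 2 (2.09 log units; beyond the scatter), each large and each moving away from compound 2 in the upward direction. The expectation in this assay is therefore a large step upward from compound 2, estimated at a 50-fold higher number from compound 2 to compound 4 (1.70 log units; beyond the scatter). Compound 4 is expected to give 150 10^-6 cm/s in this assay, with a range from 40 10^-6 cm/s to 400 10^-6 cm/s.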

Compound 4, apparent permeability: 531 10^-6 cm/s
For compound 4 the middle estimate is 3.5-fold (0.55 log units) below the measured one, outside the stated range (above it).
By their numbers in this assay, from the lowest: compound 2; then compound 3; then compounds 1 and 4 (each within the scatter of the next).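

Every earlier step replaced the whole 4-hydroxyphenyl group on the amide-type nitrogen, whereas the hydroxy to trifluoromethoxy change alters only what sits on the oxygen and still gives a 180-fold higher number from compound 2 to compound 4 (2.25 log units; beyond the scatter) in this assay on the shared core. The low number of compound 2 therefore does not require replacing the whole aromatic group: with the rest of the structure unchanged, trifluoromethyl in place of hydrogen on that oxygen is enough for a large step upward, and compound 4 now lies within the scatter of compound 1, so two different groups on the amide-type nitrogen give numbers at the same level. No measurement shown here accounts for the size of this step.

Among the compounds shown here, with only this one pair, the step cannot be divided between the loss of the hydrogen on the oxygen and the arrival of the trifluoromethyl. A methoxy group on the same oxygen would help to separate those two parts, while an amine or a carboxylic acid in place of the hydroxy group would test how far the low number of compound 2 extends to other groups at this position.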